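The compounds below may be only part of what the source reports. "The series", "measured", "known", "first", "only" and "open" are said of these compounds alone.

Measured compounds:
compound 1 `Brc1ccc(Nc2nccc(Nc3ccc4cn[nH]c4c3)n2)cc1`, 20000 nM
compound 2 `Brc1cccc(Nc2nccc(Nc3ccc4cn[nH]c4c3)n2)c1`, 17000 nM
compound 3 `CN1CCN(c2cccc(Nc3nccc(Nc4ccc5cn[nH]c5c4)n3)c2)CC1`, 6700 nM

All three were run in an ADME assay on HepG2 cells (Homo sapiens) for inhibition, read by fluorescence and resazurin assay, with a stated time of 72 h; on this read-out higher numbers stand for weaker inhibition and lower numbers for stronger inhibition. Compound 1 and compound 2 are made of the same atoms joined differently: 4-bromophenyl in place of 3-bromophenyl on a nitrogen on an aromatic ring. This gives a 1.2-fold lower number from compound 1 to compound 2 (0.07 log units; within the scatter). Compound 3 differs from compound 2 by 4-methylpiperazin-1-yl in place of bromo on an aromatic carbon, which gives a 2.5-fold lower number from compound 2 to compound 3 (0.40 log units; beyond the scatter). Compound 4 `CN1CCN(c2ccc(Nc3nccc(Nc4ccc5cn[nH]c5c4)n3)cc2)CC1` is not yet measured; it differs from compound 1 by 4-methylpiperazin-1-yl in place of bromo on an aromatic carbon. This is the same kind of change as that between compound 2 and compound 3, though the place is not identical: para to a large group in compound 4, meta to a large group in compound 3. For compound 4 the expected step is a 2.5-fold lower number from compound 1 to compound 4 (0.40 log units; beyond the scatter), resting on a 2.5-fold lower number from compound 2 to compound 3 (0.40 log units; beyond the scatter) seen for the same kind of change. Compound 4 is therefore estimated at 8000 nM in this assay, with a range of 4000 nM to 16000 nM.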

Compound 4, half-maximal inhibitory concentration: 7000 nM
Compound 4: the middle estimate sits 1.1-fold (0.06 log units) above what was measured, and the stated range covers the measured number.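

In this assay, 4-methylpiperazin-1-yl in place of bromo gives a 2.9-fold lower number from compound 1 to compound 4 (0.46 log units; beyond the scatter), so the change carries over from the core of compound 2 to the core of compound 1 with its size kept. The two steps agree: the same change on two cores in this assay, a 2.5-fold lower number (0.40 log units; beyond the scatter) from compound 2 to compound 3 and a 2.9-fold lower number (0.46 log units; beyond the scatter) from compound 1 to compound 4, 1.1-fold (0.05 log units) apart, within the scatter of two such steps. Among these compounds, this is only two pairs in a single assay, and they do not show that the step would hold on a core outside these compounds, nor do they explain why the number falls.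

The compounds shown leave open whether morpholine, an unsubstituted piperazine or a carboxylic acid in place of bromo would give a step of this size. They also leave open whether a longer chain between the aromatic ring and the piperazine would change it.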